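The source may hold more compounds than are shown below. What is called first, only, known or untested is meant among the compounds shown, and "the series" means these compounds.

Measured in an ADME assay on L6 cells (Rattus norvegicus) for cytotoxicity, read by resazurin assay, with a stated time of 72 h (on this read-out higher numbers stand for weaker inhibition and lower numbers for stronger inhibition), each entry a limit of the assay and not a number:

- Compound 1 `OC(c1ccc(Cl)cc1)(c1cncnc1)c1ccccc1F`: > 100000 nM
- Compound 2 `OC(c1ccc(Cl)cc1)(c1cccnc1)c1ccccc1F`: > 100000 nM
- Compound 3 `OC(c1ccc(Cl)cc1)(c1cnccn1)c1ccccc1Cl`: > 100000 nM

Compound 2 stands only at a limit, > 100000 nM, so its true position in this assay is not known. The same holds across the series, which shows (the limit of > 100000 nM in this assay, at which 3 of the 3 values shown sit).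

Compound 4 `OC(c1ccc(Cl)cc1)(c1cccnc1)c1ccccc1Br` has not yet been measured in this assay. It departs from compound 2 by one exchange, bromo in place of fluoro on an aromatic carbon, so that 2-fluorophenyl becomes 2-bromophenyl.

Within the data shown here, only one measured step lies close to this comparison, a step that the two limits leave unreadable from compound 1 to compound 2. It has no readable size and concerns a different place in the molecule, so it offers no measure for the exchange in compound 4.

No step beyond the usual scatter is expected, and no direction can be favoured, because of the limit of > 100000 nM in this assay, at which 3 of the 3 values shown sit. The expected outcome is a number no higher from compound 2 to compound 4 (the limit leaves the size open). A further limit is the most likely report, and for compound 4 the estimated value is 100000 nM, with an expected range of 45000 nM to 150000 nM.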

Compound 4, half-maximal inhibitory concentration: 55200 nM
Beside the measured number, compound 4's estimate is 1.8-fold (0.26 log units) above it; measured number inside the range.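

Among these compounds, exchanging 2-fluorophenyl for 2-bromophenyl gives the first step with a readable size in this assay, an at least 1.8-fold lower number from compound 2 to compound 4 (0.25 log units; that floor lies within the scatter), whereas the step between the two earlier compounds that differ in one place cannot be read. Compound 4 is also the only compound shown with a number rather than a limit, so this place on the aromatic ring is the first at which the read-out leaves its ceiling, though the floor of the step alone does not establish a real change from fluoro to bromo. The true size of the step remains open because the value of compound 2 is bounded on one side only: the limit of > 100000 nM in this assay, at which 3 of the 4 values shown sit.

The compounds shown leave open whether another group at this place, such as an amine, a carboxylic acid or a longer chain, would give a lower number in this assay than compound 4 does. They also leave open whether the same exchange from fluoro to bromo would give a readable step with pyrimidin-5-yl in place of pyridin-3-yl.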